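Swapping the Aryl Amide Substituent on a Chromone Series

This account rests on a few compounds, and the source may have more. Where it says the series, first, only, none or still open, it means among the compounds named here.

Measured so far, in a functional assay on Huh-7 cells (Homo sapiens) for inhibition, read by MTT assay, with a stated time of 48 h; a higher number here means a weaker inhibitor, a lower number a stronger inhibitor:
compound 1, `O=C(/C=C/c1coc2cc(O)ccc2c1=O)NCc1ccccc1` — 4690 nM
compound 2, `COc1cccc(NC(=O)/C=C/c2coc3cc(OC)ccc3c2=O)c1` — 11100 nM
compound 3, `Cc1ccccc1NC(=O)/C=C/c1coc2cc(O)ccc2c1=O` — 11100 nM

Compound 2 sits level with compound 3 at the digits printed, and together they give the highest numbers of the three; compound 1 gives a lower number, the only pairing that reaches beyond the scatter. Within the data shown here, the one step measured at a single position is a 2.4-fold higher number from compound 1 to compound 3 (0.37 log units; beyond the scatter), a modest rise when the benzyl group is exchanged for 2-methylphenyl.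

Compound 4, `COc1ccc2c(=O)c(/C=C/C(=O)Nc3ccc(F)cc3)coc2c1`, differs from compound 2 only on the amide nitrogen: 4-fluorophenyl in place of 3-methoxyphenyl on an amide-type nitrogen. Among the measured compounds shown here, no measured step exchanges one substituted phenyl for another on that nitrogen, so the benzyl-to-aryl step is the nearest guide, and it was small. The expectation for the step in this assay is therefore no change beyond the scatter, a 1.1-fold lower number from compound 2 to compound 4 (0.05 log units; within the scatter). Compound 4 is accordingly estimated at 10000 nM, within a range from 4000 nM to 25000 nM.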

Compound 4, half-maximal inhibitory concentration: 33900 nM
Compound 4: middle estimate off by 3.4-fold (0.53 log units), on the low side; the measured number lies above the stated range.
By their numbers in this assay, from the lowest: compound 1; then compounds 2 and 3 (each within the scatter of the next); then compound 4.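

In this assay the exchange of 3-methoxyphenyl for 4-fluorophenyl gives a 3.1-fold higher number from compound 2 to compound 4 (0.48 log units; beyond the scatter) on the same core, so the number depends not only on whether a benzyl or a phenyl ring sits on the amide-type nitrogen but also on what that phenyl ring carries. The change alters both the substituent and its printed ring position, and this single step cannot separate the two. Nothing available explains the rise in the number.

Comparing 4-methoxyphenyl with 4-fluorophenyl, or 3-fluorophenyl with 3-methoxyphenyl, would show whether the substituent or its ring position matters more. Going by these compounds, it also remains open how the number would respond to an amine or a carboxylic acid on this phenyl ring, or to a longer chain between the ring and the amide-type nitrogen.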